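The compounds below may be only part of what the source reports. "The series", "measured", "known", "first", "only" and "open" are said of these compounds alone.

In an ADME assay on HCT-116 cells (Homo sapiens) for cytotoxicity, read by CellTiter-Glo, with a stated time of 72 h (on this read-out higher numbers stand for weaker inhibition and lower numbers for stronger inhibition), compound 1 (`CC1CCN(C2CCN(S(=O)(=O)c3cccc(N)c3)CC2)CC1`) gives > 5000 nM as a limit. Compound 2 (`CC1CCN(C2CCN(S(=O)(=O)c3cnc(Cl)s3)CC2)CC1`) gives > 10000 nM as a limit too. Compound 3 (`CC1CCN(C2CCN(S(=O)(=O)c3ccc(Cl)nc3)CC2)CC1`) gives > 10000 nM as a limit, so it stands at the limit of > 10000 nM in this assay, at which 2 of the 3 values shown sit, without a number. The change to compound 4 (`Cc1nc(Cl)sc1S(=O)(=O)N1CCC(N2CCC(C)CC2)CC1`) lies on a sulfonyl sulfur: 2-chloro-4-methyl-1,3-thiazol-5-yl in place of 6-chloropyridin-3-yl on a sulfonyl sulfur with 2-chloro-4-methyl-1,3-thiazol-5-yl in place of 6-chloropyridin-3-yl. Going by the values given here, three measured steps bear on this change: a step that the two limits leave unreadable from compound 1 to compound 2 and a step that the two limits leave unreadable from compound 1 to compound 3 and a step that the two limits leave unreadable from compound 2 to compound 3 all lack a readable size. No direction can be drawn from them. The expected step is a number no higher from compound 3 to compound 4 (the limit leaves the size open) and none beyond the scatter is anticipated in this assay for this change. Compound 4 is estimated at 10000 nM with a range from 4000 nM to 20000 nM and is expected to be reported as a limit.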

Compound 4, half-maximal inhibitory concentration: > 10000 nM
Compound 4: only a limit was reported; the forecaster's own chance of this, stated with the estimate: 85%; the middle value sits exactly at the limit.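

Going by these compounds alone, compound 4 gives > 10000 nM, which is a limit, so no step from compound 1, compound 2 or compound 3 to compound 4 can be read. The compounds shown leave open whether any of these groups on the sulfonyl sulfur changes cytotoxicity.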